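From dimethylamino to diethylamino: compound 3 awaits measurement

The compounds below may be only part of what the source reports. "The series", "measured", "known", "first", "only" and "open" are said of these compounds alone.

- Compound 1 `CCN(CC)CCNC(=O)c1ccc(C(CC)(CC)c2ccc(OCC(O)C(C)(C)C)c(C)c2)n1CC`: 490 nM
- Compound 2 `CCn1c(C(=O)NCCCN(C)C)ccc1C(CC)(CC)c1ccc(OCC(O)C(C)(C)C)c(C)c1`: 360 nM

Both compounds were tested in a functional assay on HepG2 cells (Homo sapiens), read by MTT assay, with a stated time of 48 h; on this read-out lower numbers stand for stronger inhibition and higher numbers for weaker inhibition. For the measured compounds named here, compound 2, at 360 nM, lies within the scatter of compound 1, the only other measured compound, so the two cannot be told apart on these numbers.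

Compound 3 `CCN(CC)CCCNC(=O)c1ccc(C(CC)(CC)c2ccc(OCC(O)C(C)(C)C)c(C)c2)n1CC` has not yet been measured. Its difference from compound 2 is diethylamino in place of dimethylamino on a saturated chain carbon, three bonds along the chain from an amide-type nitrogen.

Going by the values given here, only one measured step bears on this change: a 1.4-fold lower number from compound 1 to compound 2 (0.13 log units; within the scatter). That step also exchanges diethylamino and dimethylamino ends, but it stays within the scatter. It is an imperfect guide, since the exchange there sits at a different place along the chain. Still, compound 1, which carries diethylamino, gives 490 nM, and nothing measured points to a large shift.

The expected step is a 1.2-fold higher number from compound 2 to compound 3 (0.07 log units; within the scatter), which is estimated to stay within the scatter. In this assay the estimated value for compound 3 is 420 nM, with an expected range from 200 nM to 850 nM.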

Compound 3, half-maximal inhibitory concentration: 1100 nM
The estimate for compound 3 lay 2.6-fold (0.42 log units) below the measured number; measured number above the stated range.
By their numbers in this assay, from the lowest: compounds 2 and 1 (each within the scatter of the next); then compound 3.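

In this assay, the exchange of 3-(dimethylamino)propyl for 3-(diethylamino)propyl gives a 3.1-fold higher number from compound 2 to compound 3 (0.49 log units; beyond the scatter), so on this chain, at the place three bonds along from the amide-type nitrogen, the size of the two alkyl groups on the amine does count, which the earlier pair could not show. With the diethylamino end kept, the step from 2-(diethylamino)ethyl to 3-(diethylamino)propyl gives a 2.2-fold higher number from compound 1 to compound 3 (0.35 log units; beyond the scatter), so chain length also counts, and compound 3 stands apart from the two compounds that could not be told apart. No measurement offered here accounts for either step.

On these data alone, the 2-(dimethylamino)ethyl chain on the shared core stays open, and with it whether the exchange of dimethylamino for diethylamino carries the same weight on the shorter chain as on the longer one. Also open, as far as these compounds go, is how a longer chain such as 4-(dimethylamino)butyl, or an amine end closed into a ring such as pyrrolidine or morpholine, would read in this assay.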